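The compounds below may be only part of what the source reports. "The series", "measured", "known", "first", "only" and "open" are said of these compounds alone.

Values in an ADME assay on liver (Mesocricetus auratus) for metabolic stability, using microsomes (a lower number here means slower removal, a higher number faster removal of the compound), for the measured compounds:
- Compound 1 `O=C(NCc1ccccc1)Nc1[nH]nc(-c2ccccn2)c1Cl` gives > 400 mL.min-1.g-1 as a limit of the assay
- Compound 2 `COc1ccc(C(=O)Nc2[nH]nc(-c3ccccn3)c2C2CC2)cc1` gives > 100 mL.min-1.g-1 as a limit of the assay
- Compound 3 `O=C(Nc1cc(-c2ccccn2)n[nH]1)N1CCC(c2cccc(F)c2)CC1` gives 207 mL.min-1.g-1 as a number

Compound 3 at 207 mL.min-1.g-1 is the only one of the three with an actual number in this assay. The values of compound 1 and compound 2 are limits of the assay. Within the data shown here, no two measured compounds differ in one place alone, so no measured step bears on the change that follows.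

Compound 4 `N#Cc1ccc(C2CCN(C(=O)Nc3cc(-c4ccccn4)n[nH]3)CC2)cc1` has not yet been measured. It differs from compound 3 by having 4-cyanophenyl in place of 3-fluorophenyl on a saturated ring carbon of a six-membered non-aromatic ring with 1 nitrogen. The rest of the structure is unchanged.

Among the measured compounds shown here, with no measured step to draw on, the expectation rests on compound 3 at 207 mL.min-1.g-1 and on this single replacement. No shift beyond the usual scatter is expected in this assay and the estimated step (a 1.2-fold lower number from compound 3 to compound 4 (0.09 log units; within the scatter)) is accordingly small. A limit rather than a number also remains possible for compound 4, as seen with compound 1 and compound 2. Compound 4 is expected at 170 mL.min-1.g-1 with an estimated range from 70 mL.min-1.g-1 to 400 mL.min-1.g-1 for the coming measurement.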

Compound 4, intrinsic clearance in microsomes: 80.8 mL.min-1.g-1
Estimate against measurement, compound 4: 2.1-fold (0.32 log units) above, and the stated range covers the measured number.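

In this assay the replacement of 3-fluorophenyl by 4-cyanophenyl on a saturated ring carbon gives a 2.6-fold lower number from compound 3 to compound 4 (0.41 log units; beyond the scatter), and this is the first step among the compounds shown that can be read in one place. It shows that the group carried on this ring carbon is not indifferent in this read-out: compound 3 and compound 4 share all the rest of their structure, and this single replacement moves the number beyond the scatter, though only modestly. Nothing measured among these compounds gives a reason for the step.

The replacement changes both the group on the phenyl ring and its place, so the two compounds cannot separate what the nitrile contributes from what its place contributes, and a 3-cyanophenyl, a 4-fluorophenyl or an unsubstituted phenyl would be needed to tell them apart. On these data alone, it also remains open whether the step would carry over to another core, such as the core of compound 1, or to a carboxylic acid or an amine on the same phenyl ring.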